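Para substituent swap at the aryl end of the series

A few compounds are considered here, and "the series" means these few. Any claim that something is new, unique, unknown or untested is made for them only; others in the source may bear on it.

Going by the values given here, compound 1 `CC1=CC[C@H](C(C)(C)NC(=S)NN)CC1` carries the shared core without an aryl group; in a functional assay on PC-3 cells (Homo sapiens) for inhibition, read by sulforhodamine B assay, with a stated time of 48 h (on this read-out higher numbers stand for weaker inhibition of growth and lower numbers for stronger inhibition of growth), compound 1 reaches only a limit, > 100000 nM, and is the single compound at the limit of > 100000 nM in this assay, at which 1 of the 3 values shown sits. Compound 2 `COc1ccc(/C=N/NC(=S)NC(C)(C)[C@H]2CC=C(C)CC2)cc1` gives 1200 nM in this assay. Among the compounds with values here, compound 3 `CC1=CC[C@H](C(C)(C)NC(=S)N/N=C/c2ccc(O)cc2)CC1` gives 53800 nM, the highest of the two numbers reported, and the only measured step, a 45-fold higher number from compound 2 to compound 3 (1.65 log units; beyond the scatter), separates it from compound 2. Compound 4 `CC1=CC[C@H](C(C)(C)NC(=S)N/N=C/c2ccc(F)cc2)CC1` differs from compound 3 by fluoro in place of hydroxy on an aromatic carbon. Within the data shown here, no measured step exchanges hydroxy for fluoro, so the step from compound 2 to compound 3 is the only guide: removing the methyl from the oxygen cost a large amount, and the hydroxy is now removed altogether. Compound 4 is therefore expected to recover part of that loss, and the expected step is a 9.0-fold lower number from compound 3 to compound 4 (0.95 log units; beyond the scatter). Compound 4 is estimated at 6000 nM, with a range from 1200 nM to 30000 nM.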

Compound 4, concentration for total growth inhibition: < 900 nM
Compound 4 was reported as a limit (the forecaster's own chance of this, stated with the estimate: 5%); middle value at least 6.6-fold (0.82 log units) from the limit.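

In this assay, fluoro in place of hydroxy gives an at least 59-fold lower number from compound 3 to compound 4 (1.77 log units; beyond the scatter), so at this position on the aromatic ring a group with no hydrogen-bond donor and no hydrogen-bond acceptor is compatible with growth inhibition, and compound 3 stands apart from both compound 2 and compound 4. Against the methoxy group, fluoro gives an at least 1.3-fold lower number from compound 2 to compound 4 (0.12 log units; that floor lies within the scatter), which sets no order between compound 2 and compound 4. The result for compound 4 is a limit, not a number: the limit of < 900 nM in this assay, at which 1 of the 4 values shown sits.

Open, from the compounds shown here alone, is how far the true value of compound 4 lies from that limit, and whether an amine or a carboxylic acid at this position would track hydroxy or fluoro. Also open, going by these compounds, is whether a longer chain on the oxygen, such as ethoxy, would track methoxy.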